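A few compounds are considered here, and "the series" means these few. Any claim that something is new, unique, unknown or untested is made for them only; others in the source may bear on it.

Measured compounds:
Compound 1 `COc1ccc2[nH]c(-c3ccccc3F)cc(=O)c2c1O`: 110 nM
Compound 2 `COc1ccc2[nH]c(-c3cccc(F)c3)cc(=O)c2c1O`: 80 nM
Compound 3 `COc1cc2c(=O)cc(-c3ccccc3F)[nH]c2cc1O`: 4400 nM

Compound 1 and compound 2 share one core, while compound 3 is built on another; the difference between the two cores is not broken down here. In a functional assay on NCI-H460 cells (Homo sapiens) for cytotoxicity, read by MTT assay, with a stated time of 48 h (on this read-out higher numbers stand for weaker inhibition and lower numbers for stronger inhibition), compound 1 gives 110 nM, compound 2 gives 80 nM and compound 3 gives 4400 nM. The change from compound 1 to compound 2 is 3-fluorophenyl in place of 2-fluorophenyl on an aromatic carbon and it gave a 1.4-fold lower number from compound 1 to compound 2 (0.14 log units; within the scatter). Compound 4 `COc1cc2c(=O)cc(-c3cccc(F)c3)[nH]c2cc1O` carries the same change on the core of compound 3, namely (3-fluorophenyl in place of 2-fluorophenyl on an aromatic carbon). Since the earlier step was small, compound 4 is expected to show a step of about a 1.3-fold lower number from compound 3 to compound 4 (0.12 log units; within the scatter), resting on a 1.4-fold lower number from compound 1 to compound 2 (0.14 log units; within the scatter). Compound 4 is therefore estimated at 3300 nM, with a likely range from 1200 nM to 9000 nM.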

Compound 4, half-maximal inhibitory concentration: 4800 nM
The estimate for compound 4 lay 1.5-fold (0.16 log units) below the measured number; measured number inside the range.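

On the core of compound 3, 3-fluorophenyl in place of 2-fluorophenyl gave a 1.1-fold higher number from compound 3 to compound 4 (0.04 log units; within the scatter) in this assay. Set beside the earlier step, the change behaved alike on the two cores, with no difference that can be told apart: the same change on two cores in this assay, a 1.4-fold lower number (0.14 log units; within the scatter) from compound 1 to compound 2 and a 1.1-fold higher number (0.04 log units; within the scatter) from compound 3 to compound 4, 1.5-fold (0.18 log units) apart, within the scatter of two such steps. Within the data shown here, this shows only that the swap did little on either core; it does not show that a change with a large step would carry over in the same way, and two cores are a narrow basis for the whole series.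

The compounds shown leave open what happens when the fluorine gives way to another group, such as chlorine, methoxy or an amine. Going by these compounds, whether any such step would transfer between these cores also remains open.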